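The source may report more compounds than this note shows. Statements on the series, on what has been measured and on what is new or still open speak of the compounds shown alone.

Compound 1 `CCCOC1=CC(=O)c2ccccc2C1=O`: 49400 nM
Compound 2 `C/C=C/C(=O)OC1=CC(=O)c2ccccc2C1=O`: 64200 nM
Compound 3 `Cc1ccc(S(=O)(=O)Oc2ccc3c(c2)C(=O)C=CC3=O)cc1`: 16400 nM

These three compounds were tested in a functional assay on KB cells (Homo sapiens) for cytotoxicity; on this read-out higher numbers stand for weaker inhibition and lower numbers for stronger inhibition. Compound 2, at 64200 nM, cannot be separated from compound 1, at 49400 nM, because the step of a 1.3-fold higher number from compound 1 to compound 2 (0.11 log units; within the scatter) does not exceed the usual scatter. Compound 3, at 16400 nM, shows a lower number than compound 2, but it differs from compound 2 in more than one place and offers no direct guide to the change at hand.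

The next compound is compound 4 `O=C(OC1=CC(=O)c2ccccc2C1=O)c1ccccc1`, which keeps the ester of compound 2 and changes only its acyl end, with phenyl in place of prop-1-en-1-yl on a carbonyl carbon. Among the compounds with values here, no measured step tests a phenyl group here. The closest evidence is the change on the same oxygen, a 1.3-fold higher number from compound 1 to compound 2 (0.11 log units; within the scatter), which stayed within the scatter. On that single precedent, no shift beyond the scatter is expected in this assay, and no direction is firmly favoured, although a small drop would not be surprising. The estimated change is a 1.3-fold lower number from compound 2 to compound 4 (0.13 log units; within the scatter). For compound 4 the expected value is 48000 nM, with an estimated range from 20000 nM to 100000 nM.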

Compound 4, half-maximal inhibitory concentration: 36900 nM
Estimate against measurement, compound 4: 1.3-fold (0.11 log units) above, within the range that was stated.
By their numbers in this assay, from the lowest: compound 3; then compounds 4, 1 and 2 (each within the scatter of the next).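

In this assay, the acyl end of the ester can carry an aromatic ring: with phenyl in place of prop-1-en-1-yl on the carbonyl carbon, the result is a 1.7-fold lower number from compound 2 to compound 4 (0.24 log units; within the scatter). Within the data shown here, the earlier compounds had tested this oxygen only with a propyl group and an open-chain acyl group, so this is the first sign that a ring of six carbons, replacing a chain of three, does not move the read-out beyond the scatter. Together with a 1.3-fold higher number from compound 1 to compound 2 (0.11 log units; within the scatter), it makes two steps at this site that stay within the scatter, and none of the compounds shown goes against that, though no measurement of any property bears on this result and nothing here accounts for it.

Still open, as far as these compounds go, is whether an amine or a carboxylic acid carried on the phenyl group, or a longer chain at the acyl end, would give a step beyond the scatter. Compound 3, at 16400 nM, differs from the other compounds in more than one place, and the compounds shown do not tell which of those differences goes with its value.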